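The source may hold more compounds than are shown below. What is called first, only, known or untested is meant among the compounds shown, and "the series" means these compounds.

Compound 1 `COc1ccc(-c2cnc(NC(=O)c3ccccc3OC)n2C)cc1` and compound 2 `CCC(=O)Nc1ncc(-c2ccc(OC)cc2)n1C` share a core and differ only on the carbonyl carbon. In a toxicity assay on THP-1 cells (Homo sapiens) for inhibition (on this read-out higher numbers stand for lower toxicity in this test and lower numbers for higher toxicity in this test), compound 1 gives > 100000 nM and this is a limit of the test rather than a number. In this assay compound 2 gives > 100000 nM and this too is a limit. Among the compounds with values here, the step that the two limits leave unreadable from compound 1 to compound 2 therefore cannot be read in size, and the only evidence the measured pair offers is the limit of > 100000 nM in this assay, at which 2 of the 2 values shown sit, which fixes no direction. Compound 3 `COc1ccc(-c2cnc(NC(=O)c3ncc[nH]3)n2C)cc1` is the next member, and the change from compound 2 is 1H-imidazol-2-yl in place of ethyl on a carbonyl carbon on the carbonyl carbon whose other neighbour is the amide-type nitrogen. Within the data shown here, no measured step bears on this exchange with a readable size. Compound 3 is accordingly expected to remain at the limit, with an estimated 100000 nM and a range from 30000 nM to 300000 nM in this assay. The expected step of a number no higher from compound 2 to compound 3 (the limit leaves the size open) is thus none beyond the scatter.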

Compound 3, half-maximal cytotoxic concentration: > 100000 nM
Compound 3: only a limit was reported; the forecaster's own chance of this, stated with the estimate: 75%; the middle value sits exactly at the limit.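

In this assay compound 3 gives > 100000 nM, and this is a limit of the test. Within the data shown here, no step among compound 1, compound 2 and compound 3 can be read in size. The compounds shown leave open whether any group on the carbonyl carbon would bring a readable number.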